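The source may report more compounds than this note shows. Statements on the series, on what has been measured and on what is new or still open speak of the compounds shown alone.

Measured compounds in this series:

Compound 1 `C/C=C1/[C@H](O[C@@H]2O[C@H](CO)[C@@H](O)[C@H](O)[C@H]2O)OC=C(C(=O)OC)[C@H]1CC(=O)O`. In a functional assay on SK-BR-3 cells (Homo sapiens) for antiproliferative activity, read by MTT assay, with a stated time of 72 h (on this read-out higher numbers stand for weaker inhibition and lower numbers for stronger inhibition), compound 1 gives > 15000 nM, which is a limit of the assay and not a number.

Compound 2 `C/C=C1/[C@H](O[C@@H]2O[C@H](CO)[C@@H](O)[C@H](O)[C@H]2O)OC=C(C(=O)OC)[C@H]1CC(=O)OC`. In this assay compound 2 gives > 15000 nM, again a limit rather than a number.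

Compound 3 `C/C=C1/[C@H](O[C@@H]2O[C@H](COC(C)=O)[C@@H](OC(C)=O)[C@H](OC(C)=O)[C@H]2OC(C)=O)OC=C(C(=O)OC)[C@H]1CC(=O)OC`. In this assay compound 3 gives > 15000 nM, also a limit and not a number.

Compound 2 and compound 1 differ by one change, (hydrogen in place of methyl on an oxygen next to a carbonyl group). The step that the two limits leave unreadable from compound 2 to compound 1 cannot be read, since both ends are limits. How the core of compound 3 differs from that of compound 2 is not broken down here; the two differ in more than one place.

Not yet measured is compound 4 `C/C=C1/[C@H](O[C@@H]2O[C@H](COC(C)=O)[C@@H](OC(C)=O)[C@H](OC(C)=O)[C@H]2OC(C)=O)OC=C(C(=O)O)[C@H]1CC(=O)OC`. It stands to compound 3 as compound 1 stands to compound 2: the change is hydrogen in place of methyl on an oxygen next to a carbonyl group, the same change at the same kind of place, an oxygen next to a carbonyl group whose other neighbours are the carbonyl carbon. Read one bond further out, the change from compound 2 to compound 1 also reads (methoxycarbonyl)methyl to carboxymethyl, which the change from compound 3 to compound 4 does not.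

Within the data shown here, for compound 4 the step that the limit leaves unreadable from compound 3 to compound 4 is expected to be unreadable in the same way, because every value in hand sits at the limit of > 15000 nM in this assay, at which 3 of the 3 values shown sit, and the one earlier instance of this change moved nothing that could be seen. Compound 4 is estimated at 20000 nM in this assay, between 8000 nM and 60000 nM, most likely reported only as a limit.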

Compound 4, half-maximal inhibitory concentration: > 20000 nM
Compound 4: no number, only a limit (the forecaster's own chance of this, stated with the estimate: 85%); the middle value sits exactly at the limit.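

In this assay compound 4 gives > 20000 nM, a limit and not a number. Compound 3 gives > 15000 nM, also a limit, so no size can be read for the step between compound 3 and compound 4. The compounds shown leave open whether hydrogen in place of methyl on an oxygen next to a carbonyl group changes anything in this assay, as none of their values is a number.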